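The source may hold more compounds than are shown below. What is called first, only, known or untested is meant among the compounds shown, and "the series" means these compounds.

Compound 1 `COc1cc(/C=N/Nc2nc(-c3ccc(Br)cc3)cs2)cc(Br)c1OC`: 27900 nM
Compound 2 `COc1cc(/C=N/Nc2nc(-c3cccc(Br)c3)cs2)cc(Br)c1OC`: 86300 nM
Compound 3 `COc1ccccc1-c1csc(N/N=C/c2ccc(F)c(F)c2)n1`: 40600 nM

All three were tested in a functional assay on U-87MG ATCC cells for inhibition, with U-87 MG (Homo sapiens) as the target, read by MTT assay, with a stated time of 48 h; a lower number here means a stronger inhibitor, a higher number a weaker inhibitor. Compound 2 gives the highest number of the three; compound 3 lies nearest and compound 1 furthest, both gaps beyond the scatter. Compound 4 `COc1cc(/C=N/Nc2nc(-c3ccc(F)c(F)c3)cs2)cc(Br)c1OC` is not yet measured and differs from compound 2 by 3,4-difluorophenyl in place of 3-bromophenyl on an aromatic carbon. Going by the values given here, no measured step makes this exchange. Among the compounds with values here, the only measured step, a 3.1-fold higher number from compound 1 to compound 2 (0.49 log units; beyond the scatter), shifts the bromine within that ring, and compound 3 also carries a 3,4-difluorophenyl, but its other parts differ, so its value gives only a loose guide. The step of a 1.7-fold lower number from compound 2 to compound 4 (0.24 log units; within the scatter) is therefore expected to be modest, most likely toward a lower number. Compound 4 is estimated at 50000 nM, within 15000 nM to 160000 nM.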

Compound 4, half-maximal inhibitory concentration: 26300 nM
For compound 4 the middle estimate is 1.9-fold (0.28 log units) above the measured one; the measured number falls inside the stated range.
By their numbers in this assay, from the lowest: compounds 4, 1 and 3 (each within the scatter of the next); then compound 2.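

At this place on the five-membered aromatic ring, the new exchange gives a 3.3-fold lower number from compound 2 to compound 4 (0.52 log units; beyond the scatter) and so shows that a change of substituents on the phenyl ring can matter here as much as moving the bromine did. Replacing 4-bromophenyl with 3,4-difluorophenyl gives a 1.1-fold lower number from compound 1 to compound 4 (0.03 log units; within the scatter) and leaves these two groups indistinguishable, so 3-bromophenyl alone stands apart among the three groups compared at this place. Nothing available explains this difference. On these data alone, what an amine, a carboxylic acid or a longer chain would do at this place remains open.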